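A few compounds are considered here, and "the series" means these few. Any claim that something is new, unique, unknown or untested is made for them only; others in the source may bear on it.

In an ADME assay on HepG2 2.2.15 cells (Homo sapiens) for cytotoxicity, read by MTT assay, with a stated time of 8 days (a lower number here means that less compound is tolerated, a higher number that more compound is tolerated), compound 2 `COC(=O)c1cc(-c2ccc(F)nc2F)nn(Cc2ccc(Cl)cc2)c1=O` stands at > 100000 nM, and this is a limit of the assay, not a number. Compound 1 `O=c1c(C2CC2)cc(-c2ccc(F)nc2F)nn1Cc1ccc(Cl)cc1` carries cyclopropyl where compound 2 carries methoxycarbonyl, and compound 1 gives a true value of 39800 nM. For the measured compounds named here, the one measured step that bears on what follows is an at least 2.5-fold higher number from compound 1 to compound 2 (0.40 log units; beyond the scatter), and its size is known only as a bound.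

The change to compound 3 `CC(C)c1cc(-c2ccc(F)nc2F)nn(Cc2ccc(Cl)cc2)c1=O` is isopropyl in place of methoxycarbonyl on an aromatic carbon. This removes the methoxycarbonyl group that separates compound 2 from compound 1 and puts a carbon-only group in its place, as cyclopropyl is in compound 1. Compound 3 is therefore expected to fall back toward compound 1 at 39800 nM, reversing most or all of the measured step. A move to a lower number in this assay, beyond the scatter, is the likely outcome, though the limit on compound 2 leaves its exact size open. The expected change is an at least 2.3-fold lower number from compound 2 to compound 3 (0.37 log units; beyond the scatter). Compound 3 is estimated at 42000 nM, with an expected range from 18000 nM to 95000 nM.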

Compound 3, half-maximal cytotoxic concentration: 56700 nM
Compound 3: middle estimate off by 1.4-fold (0.13 log units), on the low side; the range from low to high includes it.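

In this assay the position opposite the ring nitrogen now holds two different carbon-only groups, and swapping one for the other gives a 1.4-fold higher number from compound 1 to compound 3 (0.15 log units; within the scatter) and so no readable difference between cyclopropyl and isopropyl here. Compared with methoxycarbonyl, the isopropyl of compound 3 gives an at least 1.7-fold lower number from compound 2 to compound 3 (0.24 log units; that floor lies within the scatter) and thus adds a second carbon-only comparison to the one from compound 1, although this floor alone does not establish a real drop, whereas the step from cyclopropyl to methoxycarbonyl was beyond the scatter. On these data alone, both steps that involve methoxycarbonyl are known only as bounds, and the true size of each stays unknown, since compound 2 gives a limit of the assay and not a number: the limit of > 100000 nM in this assay, at which 1 of the 3 values shown sits.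

The compounds shown leave open how far above its limit compound 2 really lies, and so how large the gap to the two carbon-only groups is. They also leave open whether a carboxylic acid, an amide or an amine at this position would go with methoxycarbonyl or with isopropyl and cyclopropyl, and whether a longer chain would keep the value of compound 3.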